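The compounds below may be only part of what the source reports. "The series", "measured", "known", "first", "only" and "open" are said of these compounds alone.

Compound 1, with structure `C#CCCCCCCCCCOC(=O)c1ccn(-c2cccc(OC(=O)NCCCC)c2)c1`, gives only a limit in an assay (brain) for inhibition of Fatty-acid amide hydrolase 1 (Mus musculus), with stated times of 20 min and 15 min (on this read-out higher numbers stand for weaker inhibition and lower numbers for stronger inhibition), > 70 nM.
Compound 2, with structure `C#CCCCCCCCCCOC(=O)c1ccn(-c2cccc(OC(=O)NCCCCCCc3ccccc3)c2)c1`, gives a limit in this assay too, > 200 nM.
Compound 3, with structure `CCCCNC(=O)Oc1cccc(-c2oc(C)cc2C(N)=O)c1`, gives a number in this assay, 530 nM.

Compound 1 and compound 2 differ by the change (phenethyl in place of hydrogen on a saturated chain carbon, four bonds along the chain from an amide-type nitrogen), and the step that the two limits leave unreadable from compound 1 to compound 2 cannot be read because both values are limits, compound 1 sitting at the limit of > 70 nM in this assay, at which 1 of the 3 values shown sits, and compound 2 at the limit of > 200 nM in this assay, at which 1 of the 3 values shown sits. The difference between the core of compound 1 and the core of compound 3 is not broken down here. Compound 4, with structure `Cc1cc(C(N)=O)c(-c2cccc(OC(=O)NCCCCCCc3ccccc3)c2)o1`, is not yet measured; it carries the same change against compound 3, (phenethyl in place of hydrogen on a saturated chain carbon, four bonds along the chain from an amide-type nitrogen). With the earlier step unreadable, the expected step of a 1.5-fold lower number from compound 3 to compound 4 (0.18 log units; within the scatter) rests only on the value of compound 3, 530 nM, and is set near no change. Compound 4 is therefore estimated at 350 nM, with a range from 60 nM to 2500 nM.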

Compound 4, half-maximal inhibitory concentration: 1.7 nM
Estimate against measurement, compound 4: 210-fold (2.31 log units) above; the measured number lies below the stated range.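

On the core of compound 3, the phenethyl change produces a 310-fold lower number from compound 3 to compound 4 (2.49 log units; beyond the scatter) in this assay, so on this core it goes with much stronger inhibition. The same change on the core of compound 1 cannot be read: compound 1 and compound 2 both give only limits, not numbers. The large step therefore stands for the core of compound 3 alone, and the data do not show whether it carries from one core to another.

The compounds shown leave open how the core of compound 3 would respond to an amine, a carboxylic acid or a longer chain at the same place. They also leave open which parts of the two cores separate them in this assay.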